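The source may report more compounds than this note shows. Statements on the series, on what has been measured and on what is new or still open speak of the compounds shown alone.

Compounds 1 and 2 share one core, and compounds 3 and 4 share another. Compound 1 `O=S(=O)(/C=C/c1ccc(F)cc1)Cc1ccc(Nc2ncnc3ccccc23)cc1` and compound 2 `O=S(=O)(/C=C/c1ccc(Br)cc1)Cc1ccc(Nc2ncnc3ccccc23)cc1` form the first pair; compound 3 `COc1cc2ncnc(Nc3ccc(CS(=O)(=O)/C=C/c4ccc(F)cc4)cc3)c2cc1OC` and compound 4 `COc1cc2ncnc(Nc3ccc(CS(=O)(=O)/C=C/c4ccc(Br)cc4)cc3)c2cc1OC` form the second, and the difference between the two cores is not broken down here. In a functional assay on MCF7 cells (Homo sapiens) (on this read-out lower numbers stand for stronger inhibition of growth and higher numbers for weaker inhibition of growth), compound 1 gives 16000 nM. In this assay compound 2 gives 91000 nM. The change between them, (bromo in place of fluoro on an aromatic carbon), produced a 5.7-fold higher number from compound 1 to compound 2 (0.75 log units; beyond the scatter), a weakening of growth inhibition. For compound 3 in this assay only a limit is reported, > 100000 nM, so compound 3 stands at the limit of > 100000 nM in this assay, at which 1 of the 3 values shown sits. The change from compound 3 to compound 4 is the same one, (bromo in place of fluoro on an aromatic carbon), on the other core. Resting on the earlier step of a 5.7-fold higher number from compound 1 to compound 2 (0.75 log units; beyond the scatter) and on the limit at which compound 3 already sits, compound 4 is expected to weaken further and most likely to return only a limit again in this assay. Compound 4 is estimated at 400000 nM, within an expected span from 100000 nM to 1500000 nM. That estimate corresponds to an expected step that the limit leaves unreadable from compound 3 to compound 4.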

Compound 4, concentration for 50% growth inhibition: 32000 nM
The estimate for compound 4 lay 13-fold (1.10 log units) above the measured number; measured number below the stated range.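

In this assay, bromo in place of fluoro on an aromatic carbon gave an at least 3.1-fold lower number from compound 3 to compound 4 (0.49 log units; beyond the scatter), a step that starts from a limit of the assay and runs the opposite way to the one seen on the core of compound 1. Set side by side, the two steps differ: the same change on two cores in this assay, a 5.7-fold higher number (0.75 log units; beyond the scatter) from compound 1 to compound 2 and an at least 3.1-fold lower number (0.49 log units; beyond the scatter) from compound 3 to compound 4, at least 17-fold (1.24 log units) apart, beyond the scatter of two such steps This shows that, in these two pairs, the direction of the change was not kept from one core to the other, but two pairs do not show why the cores part or how the change would read on any further core.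

The compounds shown carry only fluoro and bromo at this place, so it stays open how chloro, a nitrile or a methyl group would read there on either core. Going by these compounds, it also stays open whether an amine or a carboxylic acid at the same place would follow the core of compound 1 or the core of compound 3.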